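Azepanyl for cycloheptyl on the shared pyrimidinone core

The compounds below may be only part of what the source reports. "The series", "measured", "known", "first", "only" and "open" are said of these compounds alone.

Compound 1 `Cc1nc2c(cnn2-c2ccccc2)c(=O)n1-c1ccc(OC(F)(F)F)cc1` and compound 2 `Cc1nc2c(cnn2-c2ccccc2)c(=O)n1C1CCCCCC1` share one core and differ in the group on the aromatic nitrogen. In an in vitro functional assay on cells for antagonist activity at metabotropic glutamate receptor 5 (Homo sapiens), read by FLIPR and calcium flux (on this read-out higher numbers stand for weaker inhibition and lower numbers for stronger inhibition), compound 1 gives only a limit, > 100000 nM. Among the measured compounds shown here, for compound 2 this assay is recorded as "not determined" (no result reported), so it stands at no number at all; the only value shown is the limit of > 100000 nM in this assay, at which 1 of the 2 values shown sits. Compound 3 `Cc1nc2c(cnn2-c2ccccc2)c(=O)n1N1CCCCCC1` carries azepan-1-yl in place of cycloheptyl on an aromatic nitrogen. For the measured compounds named here, with no measured step to rest on, no direction can be set for this change. Compound 3 is expected to give about 50000 nM, within 5000 nM to 200000 nM.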

Compound 3, half-maximal inhibitory concentration: 3600 nM
The estimate for compound 3 lay 14-fold (1.14 log units) above the measured number; the measured number lies below the stated range.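

No new step can be read for compound 3, with no reported result for compound 2 and compound 1 standing only at a limit in this assay: the limit of > 100000 nM in this assay, at which 1 of the 3 values shown sits. From the compounds shown here alone, how azepan-1-yl compares with cycloheptyl on this read-out stays open.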